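Swapping methyl for chloro on the thiophene of an inactive pair

A few compounds are considered here, and "the series" means these few. Any claim that something is new, unique, unknown or untested is made for them only; others in the source may bear on it.

Compound 1 `Fc1ccc(C2CC(c3ccc(Cl)s3)=NN2c2nc(-c3ccc(C(F)(F)F)cc3)cs2)cc1` in a functional assay on A549 cells (Homo sapiens) for antiproliferative activity, read by XTT assay, with a stated time of 24 h; on this read-out lower numbers stand for stronger inhibition and higher numbers for weaker inhibition: > 500 ug/mL, a limit of the assay, not a number.
Compound 2 `Cc1ccc(C2=NN(c3nc(-c4ccc(Br)cc4)cs3)C(c3ccc(F)cc3)C2)s1` in this assay: > 500 ug/mL, again a limit of the assay.

Compound 2 therefore stands at the top of what this assay can report, as does the only other compound shown: the limit of > 500 ug/mL in this assay, at which 2 of the 2 values shown sit. Compound 3 `Fc1ccc(C2CC(c3ccc(Cl)s3)=NN2c2nc(-c3ccc(Br)cc3)cs2)cc1` arises from compound 2 by chloro in place of methyl on an aromatic carbon. For the measured compounds named here, no measured step of this kind exists here; compound 1, which already carries the chlorothiophene, also sits at the limit. The step of a number no higher from compound 2 to compound 3 (the limit leaves the size open) is expected to be none beyond the scatter. Compound 3 is estimated at 500 ug/mL, between 200 ug/mL and 1000 ug/mL, most likely reported as a limit again.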

Compound 3, half-maximal inhibitory concentration: 62.5 ug/mL
Beside the measured number, compound 3's estimate is 8.0-fold (0.90 log units) above it; the whole stated range lies above it.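

In this assay, this thiophene carbon next to the ring sulfur now gives a readable change: chloro in place of methyl produces an at least 8.0-fold lower number from compound 2 to compound 3 (0.90 log units; beyond the scatter). Chloro alone is not enough, however: bromo in place of trifluoromethyl gives an at least 8.0-fold lower number from compound 1 to compound 3 (0.90 log units; beyond the scatter). Among these compounds, only chloro and bromo together come off the limit, and both steps have an open size, as each starts from a limit: the limit of > 500 ug/mL in this assay, at which 2 of the 3 values shown sit.

Going by these compounds, what an amine, a carboxylic acid or a longer alkyl chain would do on this thiophene carbon remains open.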